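Amide group swap on the shared core: compound 3 to compound 4

A few compounds are considered here, and "the series" means these few. Any claim that something is new, unique, unknown or untested is made for them only; others in the source may bear on it.

In a functional assay on PC-3 cells (Homo sapiens) for inhibition, read by sulforhodamine B assay, with a stated time of 72 h (a higher number here means a weaker inhibitor, a lower number a stronger inhibitor), compound 1 (`Nc1sc(-c2ccc(Cl)cc2)c(-c2ccc(Cl)cc2)c1C(=O)NC1CCC1`) gives 24800 nM and compound 2 (`CC(C)CNC(=O)c1c(N)sc(-c2ccc(Cl)cc2)c1-c1ccc(Cl)cc1`) gives 13200 nM while compound 3 (`CN1CCN(C(=O)c2c(N)sc(-c3ccc(Cl)cc3)c2-c2ccc(Cl)cc2)CC1`) gives 13100 nM on the same readout. Compound 3 lies within the scatter of both other compounds.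

Compound 4 (`Nc1sc(-c2ccc(Cl)cc2)c(-c2ccc(Cl)cc2)c1C(=O)N1CCCC1`) has pyrrolidin-1-yl in place of 4-methylpiperazin-1-yl on a carbonyl carbon. Among the measured compounds shown here, no measured compound carries pyrrolidin-1-yl, so the closest evidence is the set of changes at this same carbonyl carbon. These are a 1.9-fold lower number from compound 1 to compound 2 (0.27 log units; within the scatter) and a 1.9-fold lower number from compound 1 to compound 3 (0.28 log units; within the scatter) as well as a 1.0-fold lower number from compound 2 to compound 3 (0.00 log units; within the scatter) and all three stay within the scatter. On these three compounds, this assay has not yet separated one group on the carbonyl carbon from another. No step beyond the scatter is therefore expected, in either direction.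

The expected change is a 1.1-fold higher number from compound 3 to compound 4 (0.06 log units; within the scatter) and so remains small. For compound 4 the estimated value is 15000 nM with an expected range from 7500 nM to 30000 nM.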

Compound 4, half-maximal inhibitory concentration: 6220 nM
Beside the measured number, compound 4's estimate is 2.4-fold (0.38 log units) above it, outside the stated range (below it).
By their numbers in this assay, from the lowest: compound 4; then compounds 3, 2 and 1 (each within the scatter of the next).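

Among the compounds shown here, at the carbonyl carbon, pyrrolidin-1-yl is the first group to separate from the others in this assay, with a 2.1-fold lower number from compound 3 to compound 4 (0.32 log units; beyond the scatter), a 2.1-fold lower number from compound 2 to compound 4 (0.33 log units; beyond the scatter) and a 4.0-fold lower number from compound 1 to compound 4 (0.60 log units; beyond the scatter), so compound 4 has the lowest number of the four. Attachment through a ring nitrogen is not enough on its own to give this separation, since compound 3 also has it and stays within the scatter of compound 2. No measurement shown gives a cause for these steps.

The change from compound 3 to compound 4 alters both ring size and the hetero atom count, and these two compounds cannot tell the two apart. Piperidin-1-yl, a six-membered ring with a single nitrogen, and azetidin-1-yl, a smaller ring, remain open as tests of that question.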